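A few compounds are considered here, and "the series" means these few. Any claim that something is new, unique, unknown or untested is made for them only; others in the source may bear on it.

Values in a functional assay on B16-F10 cells (Mus musculus) for antiproliferative activity, read by ELISA and MTT assay, with a stated time of 48 h (on this read-out higher numbers stand for weaker inhibition and lower numbers for stronger inhibition), so far:

compound 1 `Cc1ccc(S(=O)(=O)NC(=O)/C=C/c2ccc(F)cc2)cc1` gives 4.8 ug/mL
compound 2 `Cc1ccc(S(=O)(=O)NC(=O)/C=C/c2ccc(Cl)cc2)cc1` gives 4.6 ug/mL
compound 3 `O=C(/C=C/c1ccc(Cl)cc1)NS(=O)(=O)c1ccc(Br)cc1` gives 2.8 ug/mL

Compound 2 sits among three values that are all within the scatter of one another. The nearest is compound 1: a 1.0-fold lower number from compound 1 to compound 2 (0.02 log units; within the scatter). The furthest is compound 3: a 1.6-fold lower number from compound 2 to compound 3 (0.22 log units; within the scatter). Nothing in these three numbers separates any compound from the others.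

Compound 4 `Cc1ccc(S(=O)(=O)NC(=O)/C=C/c2ccc(Br)cc2)cc1` has not yet been measured in this assay. It differs from compound 2 in one place: bromo in place of chloro on an aromatic carbon.

Within the data shown here, two measured steps bear on this change. The step from compound 1 to compound 2 exchanged one halogen for another at the same place on the same ring and stayed within the scatter, a 1.0-fold lower number from compound 1 to compound 2 (0.02 log units; within the scatter). The step from compound 2 to compound 3 brought bromo into the series, though on the other ring, and also stayed within the scatter, a 1.6-fold lower number from compound 2 to compound 3 (0.22 log units; within the scatter). Among the measured compounds shown here, no measured step has yet moved the number beyond the scatter.

On that basis the step to compound 4 in this assay is expected to be small, most likely none beyond the scatter: a 1.1-fold lower number from compound 2 to compound 4 (0.03 log units; within the scatter). Compound 4 is therefore estimated at 4.3 ug/mL, with a range from 2.3 ug/mL to 8 ug/mL.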

Compound 4, half-maximal inhibitory concentration: 12.1 ug/mL
Beside the measured number, compound 4's estimate is 2.8-fold (0.45 log units) below it; the measured number lies above the stated range.
By their numbers in this assay, from the lowest: compounds 3, 2 and 1 (each within the scatter of the next); then compound 4.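

In this assay, among these compounds, the change from 4-chlorophenyl to 4-bromophenyl is the first single change to pass the scatter (a 2.6-fold higher number from compound 2 to compound 4 (0.42 log units; beyond the scatter)), and the direction is towards weaker inhibition. The halogens at this place, para to a large group, are therefore not interchangeable: fluoro and chloro cannot be told apart (a 1.0-fold lower number from compound 1 to compound 2 (0.02 log units; within the scatter)), while bromo stands apart from both, also against fluoro (a 2.5-fold higher number from compound 1 to compound 4 (0.40 log units; beyond the scatter)), and bromo on the other ring gave no such shift (a 1.6-fold lower number from compound 2 to compound 3 (0.22 log units; within the scatter)), so the higher number goes with this place and not with bromo as such. Nothing measured here bears on why this one halogen exchange moves the number.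

As far as these compounds go, whether the trend across the halogens continues with iodo at this place, or whether a non-halogen group such as methoxy or an amine there would fall with fluoro and chloro or with bromo, remains open. Also open, from the compounds shown here alone, is whether bromo at this place keeps its higher number when the methyl on the other ring is replaced by bromo or a longer chain.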